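Aryl Changes and the Expected Cytotoxicity of Compound 4

A few compounds are considered here, and "the series" means these few. Any claim that something is new, unique, unknown or untested is made for them only; others in the source may bear on it.

In an ADME assay on L6 cells (Rattus norvegicus) for cytotoxicity, read by resazurin assay, with a stated time of 70 h (on this read-out lower numbers stand for stronger inhibition and higher numbers for weaker inhibition), compound 1 (`COc1cc(NC(C)CCCNC(=O)/C=C/c2ccccc2)c2ncccc2c1`) gives 18500 nM. Compound 2 (`COc1cc(NC(C)CCCNC(=O)/C=C/c2ccc(OC)c(OC)c2)c2ncccc2c1`) reaches only a limit of this assay, > 220000 nM. Compound 3 (`COc1cc(NC(C)CCCNC(=O)/C=C/c2ccccc2F)c2ncccc2c1`) gives 3500 nM, the lowest of the two numbers; the nearest measured step is a 5.3-fold lower number from compound 1 to compound 3 (0.72 log units; beyond the scatter). Compound 4 (`COc1cc(NC(C)CCCNC(=O)/C=C/c2cccc(C(F)(F)F)c2)c2ncccc2c1`) differs from compound 3 by 3-(trifluoromethyl)phenyl in place of 2-fluorophenyl on a double-bonded chain carbon bound to a double-bonded chain carbon. Two measured steps alter the same aryl group: an at least 11-fold higher number from compound 1 to compound 2 (1.07 log units; beyond the scatter) and an at least 62-fold lower number from compound 2 to compound 3 (1.79 log units; beyond the scatter), so changes at this position have moved the number in both directions by large margins. A modest step upward is therefore expected, a 2.3-fold higher number from compound 3 to compound 4 (0.36 log units; beyond the scatter). Compound 4 is estimated at 8000 nM, within 2000 nM to 40000 nM.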

Compound 4, half-maximal inhibitory concentration: 16200 nM
For compound 4 the middle estimate is 2.0-fold (0.31 log units) below the measured one, within the range that was stated.
By their numbers in this assay, from the lowest: compound 3; then compounds 4 and 1 (each within the scatter of the next). At a limit, above all of these: compound 2.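

In this assay, trifluoromethyl in place of hydrogen on the aromatic carbon gives a 1.1-fold lower number from compound 1 to compound 4 (0.06 log units; within the scatter), so a single substituent on this aryl group need not move the number, as fluoro did. 3-(Trifluoromethyl)phenyl in place of 2-fluorophenyl gives a 4.6-fold higher number from compound 3 to compound 4 (0.67 log units; beyond the scatter), so the lower number seen with fluoro is not shared by every substituted phenyl here. Compound 2 stands at a limit, so an at least 13-fold lower number from compound 2 to compound 4 (1.13 log units; beyond the scatter) gives only a bound: the limit of > 220000 nM in this assay, at which 1 of the 4 values shown sits.

As far as these compounds go, what a single methoxy, an amine or a carboxylic acid on this aryl group would do remains open. Also open, from the compounds shown here alone, is whether the gap between fluoro and trifluoromethyl follows from the group itself or from its place on the ring.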